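The source may hold more compounds than are shown below. What is called first, only, known or untested is meant among the compounds shown, and "the series" means these compounds.

Measured so far:
compound 1 `CCCC(Oc1ccc(-n2cc(C(F)(F)F)cn2)c(C)c1)c1ccc(C(=O)NCCC(=O)O)cc1`, 2.6
compound 2 `CCCC(Oc1ccc(-n2cc(Cl)cn2)cc1)c1ccc(C(=O)NCCC(=O)O)cc1`, 2.6
compound 3 `CCC(Oc1ccc(-n2cc(C(F)(F)F)cn2)cc1)c1ccc(C(=O)NCCC(=O)O)cc1`, 1.9

In a physicochemical assay for lipophilicity, using the shake flask method, at pH 7.4 (a higher number here means a more lipophilic compound, a lower number a more polar compound), compound 3 stands lowest of the three. Compound 1 gives 2.6 and compound 2 gives 2.6; both lie higher than compound 3, and in each case the gap is beyond the scatter of repeated measurements.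

Compound 4 `O=C(O)CCNC(=O)c1ccc(C(Oc2ccc(-n3cc(C(F)(F)F)cn3)cc2)C2CCCC2)cc1` has not yet been measured. It differs from compound 3 in one place: cyclopentyl in place of ethyl on a saturated chain carbon bound to an aromatic carbon and an oxygen on an aromatic ring. Among the compounds with values here, no step between two measured compounds matches this change, so the expectation rests on compound 3 alone. With a cyclopentyl entering where an ethyl leaves, the step from compound 3 to compound 4 in this assay is expected to be upward and clearly beyond the scatter, about a number 1.20 log units higher from compound 3 to compound 4 (beyond the scatter). For compound 4 the estimate is 3.1, in a range from 2.6 to 3.6.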

Compound 4, distribution coefficient: 3.3
The estimate for compound 4 lay 0.20 log units below the measured number; measured number inside the range.
By their numbers in this assay, from the lowest: compound 3; then compounds 1 and 2 (each within the scatter of the next); then compound 4.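

Within the data shown here, this is the first single-place step: in this assay cyclopentyl in place of ethyl gives a number 1.40 log units higher from compound 3 to compound 4 (beyond the scatter) and counts as a large step. The saturated chain carbon bound to an aromatic carbon and an oxygen on an aromatic ring is therefore a place where the read-out can shift widely with the group it carries.

From the compounds shown here alone, whether the step follows the carbon count or the ring remains open; a pentyl chain at this carbon would separate the two. Going by these compounds, how an amine there would read is also open. Nothing at hand explains the size of the step.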